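Swapping the amide for a cyclopentyl ester on one carbonyl

This account rests on a few compounds, and the source may have more. Where it says the series, first, only, none or still open, it means among the compounds named here.

Compound 1 `CC1=C(C(=O)C2CC2)C(c2cccs2)NC(=O)N1` was tested in an assay on membranes from CHO cells for displacement of a labelled ligand from adenosine receptor A1 (Homo sapiens), read by scintillation counting, with a stated time of 60 min, tested at 1 uM (on this read-out higher numbers stand for more inhibition at the one concentration tested (going by the name of the read-out) and lower numbers for less inhibition), where compound 1 gives 1%. Compound 2 `CC1=C(C(=O)NC(C)C)C(c2cccs2)NC(=O)N1` carries an isopropylamino group on the same carbonyl carbon, and in this assay compound 2 gives 2%. The step of a number 1 percentage points higher from compound 1 to compound 2 (within the scatter) shows that these two numbers lie within the scatter of each other, so neither compound can be set apart from the other on this read-out. Compound 3 `CC1=C(C(=O)OC2CCCC2)C(c2cccs2)NC(=O)N1` is the next variation at that position: cyclopentyloxy in place of isopropylamino on a carbonyl carbon. Going by the values given here, the only measured step that bears on this change is the one from compound 1 to compound 2, which replaced a group on the same carbonyl carbon and stayed within the scatter. On that basis the expected step of a number 1 percentage points higher from compound 2 to compound 3 (within the scatter) is none beyond the scatter, and compound 3 is estimated at 3% in this assay, in the range -5% to 15%.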

Compound 3, a percentage reported as inhibition, at one concentration (the size of the read-out at that concentration, not a potency): 9%
For compound 3 the middle estimate is 6 percentage points below the measured one; the measured number falls inside the stated range.
By their numbers in this assay, from the lowest: compounds 1, 2 and 3 (each within the scatter of the next).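

The exchange of groups gives a number 7 percentage points higher from compound 2 to compound 3 (within the scatter) in this assay, and the comparison with the cyclopropyl compound gives a number 8 percentage points higher from compound 1 to compound 3 (within the scatter) on the same read-out. So this carbonyl carbon has now carried an oxygen-linked group as well as carbon-linked and nitrogen-linked ones, and no step among the three lies beyond the scatter. Even the loss of the hydrogen-bond donor of isopropylamino and the arrival of a five-membered non-aromatic ring of carbon only leave the number within the scatter, and nothing available here offers an explanation for the result.

Going by these compounds, whether any group at this place can give clear inhibition at the one concentration tested remains open. A carboxylic acid, a piperidine amide or a longer straight-chain ester on the same carbonyl carbon would extend the comparison.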